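The source may report more compounds than this note shows. Statements on the series, on what has been measured and on what is new or still open speak of the compounds shown alone.

Working notes. In a functional assay on Malme-3M cells (Homo sapiens) for inhibition, read by sulforhodamine B assay, with a stated time of 48 h, tested at 10 uM (on this read-out lower numbers stand for a stronger effect and higher numbers for a weaker effect at the one concentration tested), compound 1 `COc1cc(Cl)cc(-c2nn(-c3cccc(NC(=O)c4ccc(Cl)c(Cl)c4)c3)cc2-c2ccncc2)c1` gives 96.4%, whereas compound 2 `COc1cc(Cl)cc(-c2nn(-c3cccc(NC(=O)Nc4cccc(C(F)(F)F)c4)c3)cc2-c2ccncc2)c1` gives -16.6%. Within the data shown here, compound 2 stands lowest of the two numbers so far; its nearest neighbour is compound 1, and the one measured step, a number 113 percentage points lower from compound 1 to compound 2 (beyond the scatter), is the only comparison available. Compound 3 `COc1cc(Cl)cc(-c2nn(-c3cccc(NC(=O)c4cccc(C(F)(F)F)c4)c3)cc2-c2ccncc2)c1` is not yet measured. Compound 3 differs from compound 2 by 3-(trifluoromethyl)phenyl in place of (3-(trifluoromethyl)phenyl)amino on a carbonyl carbon, so compound 3 keeps the carbonyl-to-nitrogen linkage of compound 1 while carrying the aryl ring of compound 2. The step from compound 1 to compound 2 changed both the aryl ring and the linkage at once, so it bears on this step only in part. Among the measured compounds shown here, since the amide of compound 1 gave 96.4%, a large upward step a number 76.6 percentage points higher from compound 2 to compound 3 (beyond the scatter) is expected, though its size is uncertain because the single step of a number 113 percentage points lower from compound 1 to compound 2 (beyond the scatter) confounds two changes. Compound 3 is estimated at 60%, within 5% to 100%.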

Compound 3, a percentage reported as activity, at one concentration (the size of the read-out at that concentration, not a potency): 92.4%
The estimate for compound 3 lay 32.4 percentage points below the measured number; the range from low to high includes it.
By their numbers in this assay, from the lowest: compound 2; then compounds 3 and 1 (each within the scatter of the next).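

In this assay, holding the 3-(trifluoromethyl)phenyl ring fixed and replacing (3-(trifluoromethyl)phenyl)amino with 3-(trifluoromethyl)phenyl on the carbonyl carbon gives a number 109 percentage points higher from compound 2 to compound 3 (beyond the scatter), so the change in linkage alone accounts for a large step in this pair. The ring exchange at the same place, 3-(trifluoromethyl)phenyl in place of 3,4-dichlorophenyl, gives a number 4 percentage points lower from compound 1 to compound 3 (within the scatter), so this ring change does not separate the two amides. No measurement is available that explains why the linkage matters.

As far as these compounds go, it remains open whether the amino linkage gives the same large step with other rings, such as (3,4-dichlorophenyl)amino on the carbonyl carbon. From the compounds shown here alone, it is also open whether an oxygen or methylene linkage there would read like compound 2 or compound 3.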